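Methyl in place of hydrogen on compound 2

A few compounds are considered here, and "the series" means these few. Any claim that something is new, unique, unknown or untested is made for them only; others in the source may bear on it.

In a physicochemical assay for lipophilicity, measured as octanol-water partition (on this read-out higher numbers stand for higher lipophilicity and lower numbers for lower lipophilicity), compound 2 `Cc1ccc(-c2c(C#N)[n+]([O-])c3ccccc3[n+]2[O-])cc1` stands highest of the two measured compounds at 2.09, with compound 1 `N#Cc1c(-c2ccco2)[n+]([O-])c2ccccc2[n+]1[O-]` at 0.582. Compound 3 `Cc1ccc(-c2c(C#N)[n+]([O-])c3cc(C)ccc3[n+]2[O-])cc1` differs from compound 2 by methyl in place of hydrogen on an aromatic carbon. For the measured compounds named here, only one measured step bears on this, and only loosely: a number 1.51 log units higher from compound 1 to compound 2 (beyond the scatter), a large step for 4-methylphenyl in place of furan-2-yl on an aromatic carbon. The present change is smaller than that exchange. For compound 3 a modest rise in this assay is expected, a number 0.41 log units higher from compound 2 to compound 3 (beyond the scatter). Compound 3 is estimated at 2.5, with a range of 2.15 to 2.9.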

Compound 3, partition coefficient: 2.33
Compound 3: the middle estimate sits 0.17 log units above what was measured; the measured number falls inside the stated range.
By their numbers in this assay, from the lowest: compound 1; then compounds 2 and 3 (each within the scatter of the next).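

In this assay, methyl in place of hydrogen on this aromatic carbon of the shared core gives a number 0.24 log units higher from compound 2 to compound 3 (within the scatter). For the compounds shown here, this is the first reading on the six-membered aromatic ring of carbon only, and here, unlike at the earlier aromatic-carbon exchange, the single added carbon does not separate the two compounds beyond the scatter. No measurement at hand offers an explanation for this result. On these data alone, whether an amine or a carboxylic acid at this position would differ from hydrogen beyond the scatter remains open. So does whether methyl on other carbons of this ring would give a similar step.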